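The compounds below may be only part of what the source reports. "The series", "measured", "known", "first", "only" and "open" are said of these compounds alone.

For the measured compounds named here, in a functional assay on MCF7 cells (Homo sapiens) for antiproliferative activity, read by MTT assay, with a stated time of 48 h (a lower number here means a stronger inhibitor, a higher number a weaker inhibitor), three compounds of one series have numbers so far. Compound 1 `COc1ccc(-c2nn(-c3ccccc3)cc2CNc2ccc(Br)cc2)cc1` gives 7020 nM. Compound 3 `Cc1ccc(NCc2cn(-c3ccccc3)nc2-c2ccc(C)cc2)cc1` gives 7260 nM, which lies within the scatter of the value for compound 1. Compound 2 `Cc1ccc(NCc2cn(-c3ccccc3)nc2-c2ccc(Cl)cc2)cc1` gives 3110 nM, the lowest number of the three. Compound 1 therefore stands level with compound 3, and both sit above compound 2.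

The next compound, compound 4 `COc1ccc(-c2nn(-c3ccccc3)cc2CNc2ccc(F)cc2)cc1`, departs from compound 1 in a single place: fluoro in place of bromo on an aromatic carbon. Fluoro takes the place of bromo on an aromatic carbon, para to a large group, so that (4-bromophenyl)amino becomes (4-fluorophenyl)amino.

Going by the values given here, only one measured step bears on this change, and only loosely: a 2.3-fold higher number from compound 2 to compound 3 (0.37 log units; beyond the scatter). That modest step also exchanges one small group for another on an aromatic carbon, but it involves chloro and methyl at another place in the molecule. Among the compounds with values here, no measured pair exchanges bromo or fluoro, so the data give no direction for this change. A shift of similar modest size cannot be ruled out in either direction, but none beyond the scatter is expected. The estimated step is a 1.1-fold lower number from compound 1 to compound 4 (0.03 log units; within the scatter), which is expected to stay within the scatter. For compound 4 the estimated value is 6500 nM, with an expected range from 2800 nM to 15000 nM.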

Compound 4, half-maximal inhibitory concentration: 5980 nM
Estimate against measurement, compound 4: 1.1-fold (0.04 log units) above; the measured number falls inside the stated range.
By their numbers in this assay, from the lowest: compounds 2, 4, 1 and 3 (each within the scatter of the next, the first and the last beyond it).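

In this assay, for the compounds shown here, the exchange of 4-bromophenyl for 4-fluorophenyl gives the first direct reading at this position (a 1.2-fold lower number from compound 1 to compound 4 (0.07 log units; within the scatter)), and the number does not move beyond the scatter. The earlier compounds shown here showed a change beyond the scatter only at another place in the molecule, where methyl replaces chloro (a 2.3-fold higher number from compound 2 to compound 3 (0.37 log units; beyond the scatter)), and they said nothing about this one; at this position, on the core of compound 1, bromo and fluoro are interchangeable as far as this read-out goes. No measurement is available here that would explain why the two halogens give such similar numbers.

What the compounds shown leave open is whether this position tolerates groups of another kind, such as a hydroxyl, an amine or a carboxylic acid, or only the two halogens seen so far. As far as these compounds go, it also remains open whether the same exchange would stay as small on a core carrying chloro at the other varied place, as compound 2 does, rather than the methoxy group of compound 1.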